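Replacing 3,5-dimethylphenyl with 2-methylphenyl on the sulfonamide

The compounds below may be only part of what the source reports. "The series", "measured", "known", "first", "only" and "open" are said of these compounds alone.

Measured in a functional assay on MCF7 cells (Homo sapiens) for antiproliferative activity, read by sulforhodamine B assay, with a stated time of 48 h; a higher number here means a weaker inhibitor, a lower number a stronger inhibitor:
- compound 1 `O=C1NCCN1c1ccc(S(=O)(=O)Nc2ccccc2)cc1`: 470 nM
- compound 2 `Cc1cc(C)cc(NS(=O)(=O)c2ccc(N3CCNC3=O)cc2)c1`: 100 nM

Compound 2 holds the lower of the two numbers in this assay, making it the stronger inhibitor of this pair. Compound 3 `Cc1ccccc1NS(=O)(=O)c1ccc(N2CCNC2=O)cc1` differs from it as follows: 2-methylphenyl in place of 3,5-dimethylphenyl on a sulfonamide nitrogen. For the measured compounds named here, the only measured step at this place is a 4.7-fold lower number from compound 1 to compound 2 (0.67 log units; beyond the scatter), with 3,5-dimethylphenyl in place of phenyl. Going by the values given here, no 2-methylphenyl compound has been measured, so this single step is only a loose guide. Compound 3 is expected to lose part of that gain, giving a higher number. The expected change is a 2.0-fold higher number from compound 2 to compound 3 (0.30 log units; within the scatter). For compound 3 the estimated value is 200 nM, with an expected range of 80 nM to 500 nM.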

Compound 3, half-maximal inhibitory concentration: 280 nM
Beside the measured number, compound 3's estimate is 1.4-fold (0.15 log units) below it; the measured number falls inside the stated range.
By their numbers in this assay, from the lowest: compound 2; then compounds 3 and 1 (each within the scatter of the next).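

In this assay, a single methyl group on the phenyl ring, as in 2-methylphenyl, gives a 1.7-fold lower number from compound 1 to compound 3 (0.22 log units; within the scatter), so this group cannot be told apart from plain phenyl. Putting it in place of 3,5-dimethylphenyl gives a 2.8-fold higher number from compound 2 to compound 3 (0.45 log units; beyond the scatter), so the earlier gain does not come with just any methyl group on this ring. No available evidence explains this difference.
The compounds shown leave open how other groups on this ring would compare, such as a chlorine atom, a methoxy group or an amine.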